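The source may report more compounds than this note shows. Statements on the series, on what has been measured and on what is new or still open speak of the compounds shown alone.

Among the measured compounds shown here, compound 2, whose structure is `CCCOC(=O)C1=C(C)NC(=S)NC1c1ccsc1`, is one of two compounds measured so far in an assay on membranes from CHO cells for displacement of a labelled ligand from adenosine receptor A1 (Homo sapiens), read by scintillation counting, with a stated time of 60 min, tested at 1 uM; a higher number here means more inhibition at the concentration tested (going by the name of the read-out), a lower number less inhibition. Its companion, compound 1, has the structure `CC1=C(C(=O)OC(C)(C)C)C(c2ccco2)NC(=S)N1`; in this assay compound 1 gives 3%. In this assay compound 2 gives 5%. The two numbers lie within the usual scatter of each other, so neither compound can be set apart from the other on the numbers shown; both sit at the low end of the scale, with very little inhibition at the concentration tested.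

The next compound, compound 3, has the structure `CC1=C(C(=O)OC(C)(C)C)C(c2ccsc2)NC(=S)N1`. It is related to compound 2 by a single alteration, the difference between the two being (tert-butyl in place of propyl on an oxygen next to a carbonyl group). Compound 1 carries the same tert-butyl group on that oxygen and gives 3%, so the shown numbers offer no sign that this exchange moves the read-out by more than the scatter. The account therefore expects a step of a number 1 percentage points lower from compound 2 to compound 3 (within the scatter), which is no step beyond the scatter. For compound 3 the estimated value in this assay is 4%, with a range from 0% to 15%.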

Compound 3, a percentage reported as inhibition, at one concentration (the size of the read-out at that concentration, not a potency): 16%
The estimate for compound 3 lay 12 percentage points below the measured number; the measured number lies above the stated range.
By their numbers in this assay, from the lowest: compounds 1 and 2 (each within the scatter of the next); then compound 3.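

In this assay, tert-butyl in place of propyl on an oxygen next to a carbonyl group gives a number 11 percentage points higher from compound 2 to compound 3 (beyond the scatter) and so shows that the group at this place can change the read-out when thiophen-3-yl is present. With tert-butyl kept, thiophen-3-yl in place of furan-2-yl on a saturated ring carbon gives a number 13 percentage points higher from compound 1 to compound 3 (beyond the scatter) and so shows that this second place matters too when tert-butyl is present, although both steps are modest. Nothing shown gives a reason for either step.

The compounds shown leave open whether the tert-butyl exchange would give a similar step with furan-2-yl in the molecule, and whether the thiophen-3-yl exchange would do so with propyl on the oxygen. On these data alone, they also leave open whether an isopropyl group or a longer chain such as butyl on that oxygen, or a phenyl ring or thiophen-2-yl on the saturated ring carbon, would raise the number further, and since compound 3 gives 16% at a single concentration, its potency remains unknown.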